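A few compounds are considered here, and "the series" means these few. Any claim that something is new, unique, unknown or untested is made for them only; others in the source may bear on it.

Measured compounds:

compound 1, `COc1cc(C(=O)c2sc(-c3ccc(Cl)cc3)cc2N)cc(OC)c1OC`: 93 nM
compound 2, `CCOc1ccc(-c2cc(N)c(C(=O)c3cc(OC)c(OC)c(OC)c3)s2)cc1`: 590 nM

Within the data shown here, in a functional assay on L1210 cells (Mus musculus) for antiproliferative activity (on this read-out higher numbers stand for weaker inhibition and lower numbers for stronger inhibition), compound 1 gives the lower of the two numbers so far; compound 2 sits apart from it by a 6.3-fold higher number from compound 1 to compound 2 (0.80 log units; beyond the scatter), a step that is beyond the scatter and changes only the group on the distal aromatic ring, ethoxy in place of chloro on an aromatic carbon.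

Compound 3, `COc1cc(C(=O)c2sc(-c3ccsc3)cc2N)cc(OC)c1OC`, is not yet measured. Compared with compound 1 the change is thiophen-3-yl in place of 4-chlorophenyl on an aromatic carbon.

Among the measured compounds shown here, no measured step exchanges the whole 4-chlorophenyl for another ring, so nothing bears directly on this change. For the measured compounds named here, the one step available, a 6.3-fold higher number from compound 1 to compound 2 (0.80 log units; beyond the scatter), shows that altering this end of the molecule can shift the number by a modest amount, and the direction of that shift was towards a higher number. On that basis a step of similar or smaller size towards a higher number is expected from compound 1 to compound 3, a 2.7-fold higher number from compound 1 to compound 3 (0.43 log units; beyond the scatter), with a wide range.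

Compound 3 is therefore estimated at 250 nM in this assay, expected to lie between 70 nM and 900 nM.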

Compound 3, half-maximal inhibitory concentration: 12 nM
Beside the measured number, compound 3's estimate is 21-fold (1.32 log units) above it, and the stated range ends above it.
By their numbers in this assay, from the lowest: compound 3; then compound 1; then compound 2.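

Working notes: in this assay, thiophen-3-yl in place of 4-chlorophenyl gives a 7.8-fold lower number from compound 1 to compound 3 (0.89 log units; beyond the scatter) and the same ring in place of 4-ethoxyphenyl gives a 49-fold lower number from compound 2 to compound 3 (1.69 log units; beyond the scatter), so this aromatic carbon next to the ring sulfur can move the number down as well as up. The earlier step showed only a rise on changing the group on the distal aromatic ring, whereas these steps show that a six-membered aromatic ring of carbon only is not needed for a low number, and that the five-membered ring with 5 heavy atoms gives the lowest number of the three compounds. No measurement shown here accounts for the drop.

Ring size and the ring sulfur change together in these steps, so the compounds shown do not separate them; unsubstituted phenyl, thiophen-2-yl or furan-3-yl at this carbon would bear on that. Also open, as far as these compounds go, is how the number responds to a methyl group or an amine on the thiophen-3-yl ring itself.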